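Closing the amide nitrogen into an azetidine ring

The source may hold more compounds than are shown below. What is called first, only, known or untested is meant among the compounds shown, and "the series" means these compounds.

A small series sharing one core was examined in a functional assay on the whole organism with Rattus norvegicus as the target, at a dose of 20 mg/kg by the oral route; on this read-out higher numbers stand for more inhibition at the one dose given (going by the name of the read-out) and lower numbers for less inhibition. Compound 1 `O=C(/C=C1\CCc2ccc(F)cc21)NCCO` gives 42%, compound 2 `CON(C)C(=O)/C=C1\CCc2ccc(F)cc21` gives 6%, and compound 3 `CCN(C)C(=O)/C=C1\CCc2ccc(F)cc21` gives 20%. On these numbers compound 3 stands second of the three: the step of a number 14 percentage points higher from compound 2 to compound 3 (beyond the scatter) lies beyond the scatter, as does the step of a number 22 percentage points lower from compound 1 to compound 3 (beyond the scatter), and the largest change seen is a number 36 percentage points lower from compound 1 to compound 2 (beyond the scatter).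

Compound 4 `O=C(/C=C1\CCc2ccc(F)cc21)N1CCC1` is the next member. It differs from compound 3 by azetidin-1-yl in place of ethyl(methyl)amino on a carbonyl carbon. Among the compounds with values here, no measured step changes an acyclic amide substituent into a ring, so the comparisons that bear on it are indirect: the two tertiary amides, compound 2 and compound 3, sit well under compound 1, and their own step a number 14 percentage points higher from compound 2 to compound 3 (beyond the scatter) is modest. Since compound 4 keeps the tertiary amide and only reshapes its substituents, no movement beyond the scatter is expected, and the expected step is no change at the digits printed from compound 3 to compound 4 (within the scatter). Compound 4 is therefore estimated at 20%, with a likely range from 5% to 38%.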

Compound 4, a percentage reported as inhibition, in the whole organism at one dose (the size of the read-out at that dose, not a potency): 14%
For compound 4 the middle estimate is 6 percentage points above the measured one; measured number inside the range.
By their numbers in this assay, from the lowest: compounds 2, 4 and 3 (each within the scatter of the next, the first and the last beyond it); then compound 1.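

In this assay, tying the ethyl(methyl)amino group into azetidin-1-yl on the carbonyl carbon, at the same count of heavy atoms, gives a number 6 percentage points lower from compound 3 to compound 4 (within the scatter) and so makes no difference that can be read at this position. Against the methoxy(methyl)amino amide the ring gives a number 8 percentage points higher from compound 2 to compound 4 (within the scatter), while a number 28 percentage points lower from compound 1 to compound 4 (beyond the scatter) places a ring-closed amide with the two open-chain tertiary amides, all three under compound 1. No measurement offered here accounts for these numbers.

On these data alone, it remains open whether a larger ring, such as pyrrolidin-1-yl or morpholin-4-yl, would read the same as azetidin-1-yl. Also open, as far as these compounds go, is whether a simple ethylamino amide, lacking the hydroxyl group, would stay near compound 1 at 42% or fall to the level of the tertiary amides.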